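Two Methyl Groups on the Ketone-Side Phenyl Ring

A few compounds are considered here, and "the series" means these few. Any claim that something is new, unique, unknown or untested is made for them only; others in the source may bear on it.

Compound 1 `COc1cc(-c2cc(C(=O)/C=C/c3ccccc3)nc3cc(-c4ccccc4)nn23)cc(OC)c1OC`: 16300 nM
Compound 2 `COc1ccc(-c2cc(/C=C/C(=O)c3ccc(C)c(C)c3)nc3cc(-c4ccccc4)nn23)cc1OC`: 12100 nM
Compound 3 `COc1cc(-c2cc(/C=C/C(=O)c3ccccc3)nc3cc(-c4ccccc4)nn23)cc(OC)c1OC`: 34300 nM

These three compounds were tested in a functional assay on DU-145 cells (Homo sapiens) for antiproliferative activity, read by MTT assay, with a stated time of 24 h; on this read-out higher numbers stand for weaker inhibition and lower numbers for stronger inhibition. Compound 3 gives the highest number of the three, above compound 1 and compound 2. For the measured compounds named here, the only measured step involving compound 3 is a 2.1-fold higher number from compound 1 to compound 3 (0.32 log units; beyond the scatter), and it concerns a different change. Compound 4 `COc1cc(-c2cc(/C=C/C(=O)c3ccc(C)c(C)c3)nc3cc(-c4ccccc4)nn23)cc(OC)c1OC` differs from compound 3 by 3,4-dimethylphenyl in place of phenyl on a carbonyl carbon. Going by the values given here, no measured step isolates this change: compound 2 carries the same 3,4-dimethylphenyl group but with a different methoxy pattern elsewhere and gives 12100 nM, while compound 3 gives 34300 nM, so the two are not a clean comparison. Without a direct precedent, the expected step is small, a 1.6-fold lower number from compound 3 to compound 4 (0.19 log units; within the scatter). Compound 4 is therefore estimated at 22000 nM, within a range from 8000 nM to 55000 nM.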

Compound 4, half-maximal inhibitory concentration: 15400 nM
For compound 4 the middle estimate is 1.4-fold (0.15 log units) above the measured one; measured number inside the range.
By their numbers in this assay, from the lowest: compounds 2, 4 and 1 (each within the scatter of the next); then compound 3.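

For the compounds shown here, on the carbonyl carbon, 3,4-dimethylphenyl in place of phenyl gives a 2.2-fold lower number from compound 3 to compound 4 (0.35 log units; beyond the scatter) as the first clean reading of this change. With that group present, methoxy in place of hydrogen on an aromatic carbon gives only a 1.3-fold higher number from compound 2 to compound 4 (0.10 log units; within the scatter) and 2-((3,4-dimethylphenyl)carbonyl)ethenyl in place of (2-phenylethenyl)carbonyl gives a 1.1-fold lower number from compound 1 to compound 4 (0.02 log units; within the scatter) as well. Nothing available explains the step from phenyl to 3,4-dimethylphenyl.

As far as these compounds go, whether a single methyl group on that ring would serve as well remains open. So does the effect of an amine or a carboxylic acid there.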